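This account rests on a few compounds, and the source may have more. Where it says the series, first, only, none or still open, it means among the compounds named here.

Measured compounds:
compound 1 `Nc1nc2cc(N3CCCC3)ccc2cc1-c1cc(Cl)cc(Cl)c1` — 320 mL/min/kg
compound 2 `Nc1nc2cc(N3CCCCC3)ccc2cc1-c1cc(Cl)cc(Cl)c1` — 460 mL/min/kg
compound 3 `Cn1cc(-c2cc3ccc(N4CCCC4)cc3nc2N)c2ccccc21` — > 500 mL/min/kg

The study concerns an ADME assay on microsomes from liver (Mus musculus) for metabolic stability, read by HPLC, with a stated time of 4 h; a lower number here means slower removal, a higher number faster removal of the compound. In this assay compound 1 gives 320 mL/min/kg. Compound 2 differs from compound 1 by piperidin-1-yl in place of pyrrolidin-1-yl on an aromatic carbon, and this step gives a 1.4-fold higher number from compound 1 to compound 2 (0.16 log units; within the scatter). The core of compound 3 is a different one, and the difference between the two cores is not broken down here. For compound 3 the assay reports only a limit, > 500 mL/min/kg, which is the limit of this assay, (the limit of > 500 mL/min/kg in this assay, at which 1 of the 3 values shown sits).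

Compound 4 `Cn1cc(-c2cc3ccc(N4CCCCC4)cc3nc2N)c2ccccc21` has not yet been measured in this assay. It differs from compound 3 by piperidin-1-yl in place of pyrrolidin-1-yl on an aromatic carbon, the same change as between compound 1 and compound 2. Since compound 3 already sits at the limit and the earlier step, a 1.4-fold higher number from compound 1 to compound 2 (0.16 log units; within the scatter), stayed within the scatter, compound 4 is expected to remain at or beyond that limit, an expected step that the limit leaves unreadable from compound 3 to compound 4. The estimate for compound 4 in this assay is 650 mL/min/kg, expected to lie between 400 mL/min/kg and 1200 mL/min/kg.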

Compound 4, clearance: 95 mL/min/kg
Compound 4: the middle estimate sits 6.8-fold (0.84 log units) above what was measured; measured number below the stated range.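

In this assay, piperidin-1-yl in place of pyrrolidin-1-yl on an aromatic carbon gives an at least 5.2-fold lower number from compound 3 to compound 4 (0.72 log units; beyond the scatter). This change therefore does not carry over from one core to the other as a fixed step, and its outcome in this series depends on the core it is made on: the same change on two cores in this assay, a 1.4-fold higher number (0.16 log units; within the scatter) from compound 1 to compound 2 and an at least 5.2-fold lower number (0.72 log units; beyond the scatter) from compound 3 to compound 4, at least 7.5-fold (0.87 log units) apart, beyond the scatter of two such steps. It does not show the true size of the new step, whose starting point, compound 3, is a limit and not a number, nor which part of the cores sets the two steps apart: the limit of > 500 mL/min/kg in this assay, at which 1 of the 4 values shown sits.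

With two cores shown, it remains open how the same change would behave on a third core. On these data alone, it also remains open whether a morpholin-4-yl or an azepan-1-yl group in the same place would give a number closer to that of compound 4 or to the limit of compound 3 on the core they share.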